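The compounds below may be only part of what the source reports. "The series", "measured", "known", "first", "only" and "open" are said of these compounds alone.

Three congeners of the shared core all carry the methoxy oxime and differ in the chain on the charged ring. Compound 1 `CO/N=c1\[nH]cnc2c1[n+](C/C=C(\C)CCC=C(C)C)cn2C` has the shortest chain; in a functional assay on CEM/s cells (Homo sapiens) for cytotoxicity (a lower number here means a stronger inhibitor, a higher number a weaker inhibitor), compound 1 gives 27400 nM. Compound 2 `CO/N=c1\[nH]cnc2c1[n+](C/C=C(\C)CC/C=C(\C)CCC=C(C)C)cn2C` carries the longer chain, and in this assay compound 2 gives 1160 nM. Compound 3 `CO/N=c1\[nH]cnc2c1[n+](C/C=C(\C)CC/C=C(/C)CCC=C(C)C)cn2C` is the configurational isomer of that chain as drawn, and compound 3 gives 1230 nM. Compound 3 thus stands second highest of the three numbers, close to compound 2 and far from compound 1: the step of a 22-fold lower number from compound 1 to compound 3 (1.35 log units; beyond the scatter) parallels a 24-fold lower number from compound 1 to compound 2 (1.37 log units; beyond the scatter), whereas a 1.1-fold higher number from compound 2 to compound 3 (0.03 log units; within the scatter) is flat, which because of the fact that compounds 2 and 3 differ only in the configuration as drawn shows that the drawn configuration of that double bond makes no measurable difference here.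

Compound 4 `CC(C)=CCC/C(C)=C\CC/C(C)=C/C[n+]1cn(C)c2nc[nH]/c(=N\OCc3ccccc3)c21` keeps the chain of compound 3 and alters the oxime end instead: phenyl in place of hydrogen on a saturated chain carbon bound to an oxygen. Among the measured compounds shown here, none of the measured steps touches this position; the two chain-extension steps concern another part of the molecule, and the configuration step is flat. For the measured compounds named here, no measured step therefore fixes the direction or size of this change in this assay. Lacking a reference, the working expectation for compound 4 is a step of a 1.2-fold higher number from compound 3 to compound 4 (0.09 log units; within the scatter) that stays near the value of compound 3, with a wide range. The estimate for compound 4 is 1500 nM, between 400 nM and 6000 nM.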

Compound 4, half-maximal inhibitory concentration: 10000 nM
Compound 4: middle estimate off by 6.7-fold (0.82 log units), on the low side; measured number outside the range, above it.
By their numbers in this assay, from the lowest: compounds 2 and 3 (each within the scatter of the next); then compound 4; then compound 1.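

With the chain of compound 3 held fixed, methoxy to benzyloxy at the oxime end gives an 8.1-fold higher number from compound 3 to compound 4 (0.91 log units; beyond the scatter) in this assay. No earlier comparison touched this position, and it is now shown to respond to change. Phenyl in place of hydrogen on a saturated chain carbon bound to an oxygen moves the number in the opposite direction to the chain extension, a 22-fold lower number from compound 1 to compound 3 (1.35 log units; beyond the scatter), and by a smaller step, so in this pair the added phenyl gives back only part of what the longer chain gained. No measurement shown bears on why the benzyloxy compound gives the higher number.

The compounds shown leave open whether the phenyl ring itself or simply a larger group at this position sets the step, a question that an ethoxy, a propoxy or a cyclohexylmethoxy group at the oxime end would address. Also open, from the compounds shown here alone, is whether benzyloxy gives a step of similar size on the shorter chain of compound 1, and how a free hydroxy oxime compares with methoxy.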